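The source may hold more compounds than are shown below. What is called first, only, known or untested is meant among the compounds shown, and "the series" means these compounds.

Measured in an ADME assay on J774 cells (Mus musculus) for cytotoxicity, read by resazurin assay, with a stated time of 72 h; a higher number here means that more compound is tolerated, a lower number that less compound is tolerated:
- Compound 1 `C/C(=N\Nc1nc(CCl)cs1)c1ccc(Cl)c(Cl)c1`: > 50000 nM, a limit.
- Compound 2 `C/C(=N\Nc1nc(-c2ccccc2)cs1)c1ccc(Cl)c(Cl)c1`: > 50000 nM, a limit.
- Compound 3 `C/C(=N\Nc1nc(-c2ccncc2)cs1)c1ccc(Cl)c(Cl)c1`: 39800 nM.

Compound 2 has no number in this assay, only the limit > 50000 nM. This is the limit of > 50000 nM in this assay, at which 2 of the 3 values shown sit. Compound 4 `C/C(=N\Nc1nc(-c2ccc([N+](=O)[O-])cc2)cs1)c1ccc(Cl)c(Cl)c1` differs from compound 2 by nitro in place of hydrogen on an aromatic carbon.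

Among the measured compounds shown here, no measured step makes this exact change. The closest one replaces phenyl with pyridin-4-yl: an at least 1.2-fold lower number from compound 2 to compound 3 (0.09 log units; that floor lies within the scatter). Replacing chloromethyl with pyridin-4-yl gives a similar result: an at least 1.2-fold lower number from compound 1 to compound 3 (0.09 log units; that floor lies within the scatter). The remaining step gives no size: a step that the two limits leave unreadable from compound 1 to compound 2. Neither readable step shows a change beyond the scatter, so no step beyond the scatter is expected in this assay, and no direction can be firmly assigned. The expected step is an at least 1.1-fold lower number from compound 2 to compound 4 (0.07 log units; that floor lies within the scatter). For compound 4 the estimated value is 42000 nM, with an expected range from 15000 nM to 80000 nM.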

Compound 4, half-maximal cytotoxic concentration: > 50000 nM
Compound 4: only a limit was reported; the forecaster's own chance of this, stated with the estimate: 50%; at least 1.1-fold (0.07 log units) between middle value and limit.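

No step can be read from compound 2 to compound 4 in this assay, as both carry only a limit: the limit of > 50000 nM in this assay, at which 3 of the 4 values shown sit.

The compounds shown leave open whether nitro in place of hydrogen on an aromatic carbon changes the tolerated concentration at all, and in which direction.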